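From Methyl to Phenyl on a Small Heteroaromatic Core

A few compounds are considered here, and "the series" means these few. Any claim that something is new, unique, unknown or untested is made for them only; others in the source may bear on it.

Compound 1 `CC(C)(C)NCC(O)COc1ncns1`, 1% in a functional assay on the whole organism (artery, strain mongrel) for inhibition, with Canis familiaris (Canis lupus familiaris) as the target, with a stated time of 20 min, at a dose of 0.42 mg/kg by the intravenous route; on this read-out lower numbers stand for a weaker effect and higher numbers for a stronger effect at the one dose given
Compound 2 `Cc1nsc(OCC(O)CNC(C)(C)C)n1`, 12.8% in this assay

Compound 2 stands highest of the two numbers in this assay, with compound 1 nearest; the step of a number 11.8 percentage points higher from compound 1 to compound 2 (beyond the scatter) is beyond the scatter but modest. Compound 3 `CC(C)(C)NCC(O)COc1nc(-c2ccccc2)ns1` differs from compound 2 by phenyl in place of methyl on an aromatic carbon. For the measured compounds named here, the one measured step, a number 11.8 percentage points higher from compound 1 to compound 2 (beyond the scatter), concerns the same place but a much smaller group, so it guides only weakly; a small rise or no change beyond the scatter is plausible. Compound 3 is expected to give 20%, within 3% to 45%, which is estimated to mean a number 7.2 percentage points higher from compound 2 to compound 3 (within the scatter).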

Compound 3, a percentage reported as inhibition, in the whole organism at one dose (the size of the read-out at that dose, not a potency): 5.3%
Compound 3: the middle estimate sits 14.7 percentage points above what was measured; low and high end bracket the measured number.
By their numbers in this assay, from the lowest: compounds 1, 3 and 2 (each within the scatter of the next, the first and the last beyond it).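

On the aromatic carbon of the shared core, phenyl cannot be told apart from methyl in this assay, with a number 7.5 percentage points lower from compound 2 to compound 3 (within the scatter). Nor can it be told apart from hydrogen, with a number 4.3 percentage points higher from compound 1 to compound 3 (within the scatter), so adding the six-membered aromatic ring gives no clear gain at this position over either smaller group. No available data explain this result. As far as these compounds go, whether an ethyl group or an amine at this position would give a clearly larger effect remains open. So does whether these compounds would separate more clearly at other doses.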